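This account rests on a few compounds, and the source may have more. Where it says the series, first, only, none or still open, it means among the compounds named here.

Of the compounds shown here, three sharing one core have been measured. Compound 1 `O=C(NC(=S)NNc1ncnc2ccccc12)c1cccc(Cl)c1` gives 3540 nM in a functional assay on MCF7 cells (Homo sapiens) for cytotoxicity, read by MTT assay, with a stated time of 72 h; a higher number here means a weaker inhibitor, a lower number a stronger inhibitor. Compound 2 `O=C(NC(=S)NNc1ncnc2ccccc12)c1ccc(Cl)cc1` gives 5960 nM, and compound 3 `O=C(NC(=S)NNc1ncnc2ccccc12)c1ccccc1F` gives 5020 nM. Every gap among them is small: a 1.7-fold higher number from compound 1 to compound 2 (0.23 log units; within the scatter), a 1.4-fold higher number from compound 1 to compound 3 (0.15 log units; within the scatter), and a 1.2-fold lower number from compound 2 to compound 3 (0.07 log units; within the scatter). Compound 3 therefore sits among the others with no separation that the measurement can resolve.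

Compound 4 `Cc1ccccc1C(=O)NC(=S)NNc1ncnc2ccccc12` differs from compound 3 in one place: methyl in place of fluoro on an aromatic carbon. Going by the values given here, no measured step swaps a fluoro for a methyl; the three steps available only move or exchange a halogen on the same ring, and none of them reached beyond the scatter. With nothing pointing either way, the step is expected to stay within the scatter, a 1.0-fold lower number from compound 3 to compound 4 (0.00 log units; within the scatter). Compound 4 is expected to give about 5000 nM, with a plausible range from 2500 nM to 10000 nM.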

Compound 4, half-maximal inhibitory concentration: 16500 nM
Beside the measured number, compound 4's estimate is 3.3-fold (0.52 log units) below it, and the stated range ends below it.
By their numbers in this assay, from the lowest: compounds 1, 3 and 2 (each within the scatter of the next); then compound 4.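

Among the compounds shown, exchanging or moving a halogen on this ring stayed within the scatter, but in this assay putting a methyl in place of the fluoro, ortho to a large group, gives a 3.3-fold higher number from compound 3 to compound 4 (0.52 log units; beyond the scatter) and is the first change here that the measurement can resolve. The two chlorophenyl compounds point the same way, with a 2.8-fold higher number from compound 2 to compound 4 (0.44 log units; beyond the scatter) and a 4.7-fold higher number from compound 1 to compound 4 (0.67 log units; beyond the scatter) making compound 4 the weakest inhibitor of the four. Nothing available explains why a methyl and a fluoro differ at this position.

Going by these compounds, whether the higher number is specific to methyl remains open, since an ethyl, a methoxy or an amine in the same place could raise it further or bring it back. Also open, on these data alone, is whether a methyl elsewhere on this ring would give the same result.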